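The source may report more compounds than this note shows. Statements on the series, on what has been measured and on what is new or still open speak of the compounds shown alone.

Measured compounds:
compound 1, `O=C1C=C(Nc2ccccc2F)C(=O)c2c1nc1n2[C@H]2OC[C@@H](O)[C@H]2OC1` — in a functional assay on MGC-803 cells (Homo sapiens) for inhibition, read by sulforhodamine B assay (on this read-out higher numbers stand for weaker inhibition and lower numbers for stronger inhibition), compound 1 gives 2080 nM
compound 2, `O=C1C=C(Nc2ccc(C(F)(F)F)cc2)C(=O)c2c1nc1n2[C@H]2OC[C@@H](O)[C@H]2OC1` — compound 2 gives 2820 nM
compound 3, `CCOc1ccccc1NC1=CC(=O)c2nc3n(c2C1=O)[C@H]1OC[C@@H](O)[C@H]1OC3` — compound 3 gives 2450 nM

Compound 1 has the lowest of the three numbers, but all three sit within the scatter of each other: a 1.2-fold higher number from compound 1 to compound 3 (0.07 log units; within the scatter), a 1.4-fold higher number from compound 1 to compound 2 (0.13 log units; within the scatter), and a 1.2-fold lower number from compound 2 to compound 3 (0.06 log units; within the scatter). The three aryl variants on the amine nitrogen are thus indistinguishable on this read-out.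

Compound 4, `CCCN(CCC)C1=CC(=O)c2nc3n(c2C1=O)[C@H]1OC[C@@H](O)[C@H]1OC3`, differs from compound 1 as follows: dipropylamino in place of (2-fluorophenyl)amino on a double-bonded ring carbon. Going by the values given here, none of the measured steps bears directly on this change. Each exchanges one aryl group for another on the same nitrogen, and each stays within the scatter; they show only that the series has so far been flat across such exchanges. Among the compounds with values here, no measured compound lacks the aromatic ring or the hydrogen-bond donor, so the effect of dipropylamino is untested here.

Within the data shown here, with no direct precedent, the number for compound 4 is expected near the measured cluster, with wide uncertainty and some allowance for a higher number; the expected step is a 1.9-fold higher number from compound 1 to compound 4 (0.28 log units; within the scatter). Compound 4 is estimated at 4000 nM, in the range 1500 nM to 12000 nM.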

Compound 4, half-maximal inhibitory concentration: > 16000 nM
Compound 4: a limit, no number (the forecaster's own chance of this, stated with the estimate: 10%); middle value at least 4.0-fold (0.60 log units) from the limit.
By their numbers in this assay, from the lowest: compounds 1, 3 and 2 (each within the scatter of the next). At a limit, above all of these: compound 4.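

In this assay, the double-bonded ring carbon is not indifferent to every exchange: the aryl-for-aryl steps stayed within the scatter, whereas dipropylamino in place of (2-fluorophenyl)amino gives an at least 7.6-fold higher number from compound 1 to compound 4 (0.88 log units; beyond the scatter). Compound 4 stands at a limit of the assay, not at a number: the limit of > 16000 nM in this assay, at which 1 of the 4 values shown sits. This single change removes the six-membered aromatic ring and the hydrogen-bond donor together, so the compounds shown do not separate the two.

Open, as far as these compounds go, is which of these losses carries the step: propylamino would keep the donor without the ring, and methyl(phenyl)amino would keep the ring without the donor. Also open, from the compounds shown here alone, is whether the step holds for other amines lacking the donor, such as dimethylamino or morpholine.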